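This account rests on a few compounds, and the source may have more. Where it says the series, first, only, none or still open, it means among the compounds named here.

In a physicochemical assay for solubility, with a stated time of 18 h, at pH 7.4 (a higher number here means a more soluble compound, a lower number a less soluble compound), compound 1 `COc1cccc(Oc2ccc3c(NCCCNCc4cc(F)ccc4OC)ccnc3c2)c1` gives 14500 nM. Compound 2 `COc1cccc(Oc2ccc3c(NCCCNCc4ccco4)ccnc3c2)c1` gives 14500 nM, and the step of no change at the digits printed from compound 1 to compound 2 (within the scatter) shows the two to be level; together they hold the highest numbers of the three measured compounds. Compound 3 `c1ccc(Cc2ccc3c(NCCCNCc4ccco4)ccnc3c2)cc1` gives 4200 nM, the lowest of the three, so compound 1 stands at the top of this small set. The unmeasured compound 4 `COc1ccc(F)cc1CNCCCNc1ccnc2cc(Cc3cc(C)cc(C)c3)ccc12` differs from compound 1 by 3,5-dimethylbenzyl in place of 3-methoxyphenoxy on an aromatic carbon. Within the data shown here, one measured step bears on this change: a 3.5-fold lower number from compound 2 to compound 3 (0.54 log units; beyond the scatter), which exchanges the same 3-methoxyphenoxy group for a benzyl group on an aromatic carbon of the shared core. Among the measured compounds shown here, the change to compound 4 is of the same kind, with 3,5-dimethylbenzyl entering rather than benzyl; no measured pair shows what the two added methyl groups contribute. A drop of similar size, beyond the scatter and perhaps somewhat larger, is therefore expected for compound 4, amounting to an expected step of a 4.8-fold lower number from compound 1 to compound 4 (0.68 log units; beyond the scatter). Compound 4 is estimated at 3000 nM, with a range from 1000 nM to 8000 nM.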

Compound 4, solubility: 4200 nM
Beside the measured number, compound 4's estimate is 1.4-fold (0.15 log units) below it; measured number inside the range.
By their numbers in this assay, from the lowest: compounds 3 and 4 (each within the scatter of the next); then compounds 1 and 2 (each within the scatter of the next).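

Replacing 3-methoxyphenoxy on this aromatic carbon lowers the number in this assay on both side chains shown: the change gives a 3.5-fold lower number from compound 1 to compound 4 (0.54 log units; beyond the scatter) and, with benzyl entering on the furan-2-yl side chain, a 3.5-fold lower number from compound 2 to compound 3 (0.54 log units; beyond the scatter) as well. The lower number is therefore not tied to the furan-2-yl side chain, and it also appears with the 5-fluoro-2-methoxyphenyl group in place. The two steps are the same size at the digits printed, although the entering groups differ by the two methyl groups of 3,5-dimethylbenzyl.

The compounds shown leave open what those two methyl groups contribute on their own. They also leave open how a plain phenoxy or a 3-methoxybenzyl group would read on this carbon. Nothing shown gives a measured reason for the lower number.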